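Nitro for Trifluoromethyl on a Weakly Active Aniline Series

A few compounds are considered here, and "the series" means these few. Any claim that something is new, unique, unknown or untested is made for them only; others in the source may bear on it.

Measured compounds:
compound 1 `c1ccc(COc2ccccc2Nc2ncnc3cc4c(cc23)OCCOCCOCCO4)cc1`: 63300 nM
compound 2 `FC(F)(F)c1ccc(COc2ccccc2Nc2ncnc3cc4c(cc23)OCCOCCO4)cc1`: > 100000 nM
compound 3 `FC(F)(F)c1ccc(COc2cccc(Nc3ncnc4cc5c(cc34)OCCOCCO5)c2)cc1`: > 100000 nM

Going by the values given here, in a functional assay on MCF7 cells (Homo sapiens) for antiproliferative activity, read by MTT assay, with a stated time of 72 h (on this read-out lower numbers stand for stronger inhibition and higher numbers for weaker inhibition), compound 1 gives 63300 nM, the only plain number among the three. For compound 2 the assay reports only a limit, > 100000 nM. Compound 3 likewise yields only a limit, > 100000 nM, so its true potency is not pinned down. Among the compounds with values here, two of the three results therefore sit at the same boundary (the limit of > 100000 nM in this assay, at which 2 of the 3 values shown sit), and compound 3 stands there, with compound 2 beside it and compound 1 the sole compound with a measured figure.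

Compound 4 `O=[N+]([O-])c1ccc(COc2cccc(Nc3ncnc4cc5c(cc34)OCCOCCO5)c2)cc1` differs from compound 3 by nitro in place of trifluoromethyl on an aromatic carbon. Within the data shown here, no measured pair shows this swap, so the data give no direction for it. Starting from a limit, a change toward weaker inhibition could not even be seen. The step from compound 3 to compound 4 is expected to stay within scatter, a number no higher from compound 3 to compound 4 (the limit leaves the size open), most likely again ending at the limit. Compound 4 is therefore estimated at 100000 nM, between 30000 nM and 300000 nM.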

Compound 4, half-maximal inhibitory concentration: 42400 nM
Estimate against measurement, compound 4: 2.4-fold (0.37 log units) above, within the range that was stated.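

In this assay, nitro in place of trifluoromethyl on this aromatic carbon gives an at least 2.3-fold lower number from compound 3 to compound 4 (0.37 log units; beyond the scatter). Going by these compounds alone, this is the first measured pair for the swap, and it shows that the group at this place can matter: the 4-nitrobenzyl compound gives a plain number, while its 4-(trifluoromethyl)benzyl partner does not. Compound 3 has a limit and not a number, so the step has a floor but no known full size: the limit of > 100000 nM in this assay, at which 2 of the 4 values shown sit.

From the compounds shown here alone, whether an amine, a carboxylic acid or a nitrile at the same place would give a lower number still remains open. Going by these compounds, it is also open whether the same swap would change the result for compound 2, which carries trifluoromethyl as well.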